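From compound 3 to compound 4: adding trifluoromethyl

The source may hold more compounds than are shown below. What is called first, only, known or untested is meant among the compounds shown, and "the series" means these compounds.

Values in a physicochemical assay for lipophilicity; on this read-out lower numbers stand for lower lipophilicity and higher numbers for higher lipophilicity:
- compound 1 `C=C(c1cccc2ccccc12)C1CCC2(CC1)COC(Nc1ccccc1-c1ccccc1)OO2`: 7.26
- compound 2 `C=C(c1cccc2ccccc12)C1CCC2(CC1)COC(Nc1ccc(C(F)(F)F)cc1)OO2`: 6.51
- compound 3 `C=C(c1ccc2ccccc2c1)C1CCC2(CC1)COC(Nc1ccccc1)OO2`: 5.59

Of the three, compound 3 has the lowest number, at 5.59. Compound 4 `C=C(c1ccc2ccccc2c1)C1CCC2(CC1)COC(Nc1cccc(C(F)(F)F)c1)OO2` has trifluoromethyl in place of hydrogen on an aromatic carbon, meta to a large group: trifluoromethyl in place of hydrogen on an aromatic carbon. For the measured compounds named here, the one measured step, a number 0.75 log units lower from compound 1 to compound 2 (beyond the scatter), is modest but bears only indirectly, since it exchanges one substituted phenyl for another. Compound 2, which also carries trifluoromethyl, gives 6.51, though it differs from compound 3 in more than one place. A modest rise beyond the scatter is therefore expected in this assay. The estimated change is a number 0.91 log units higher from compound 3 to compound 4 (beyond the scatter). The expected value for compound 4 is 6.5, with a range of 6.1 to 6.9.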

Compound 4, partition coefficient: 6.51
Estimate against measurement, compound 4: 0.01 log units below; the measured number falls inside the stated range.
By their numbers in this assay, from the lowest: compound 3; then compounds 2 and 4 (each within the scatter of the next); then compound 1.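

Working notes: in this assay, trifluoromethyl in place of hydrogen on an aromatic carbon, meta to a large group, gives a number 0.92 log units higher from compound 3 to compound 4 (beyond the scatter) and so provides the first single-place reading of this group in the series. The earlier step, by contrast, only exchanged one substituted phenyl for another. No supporting data explain the size of this step.

Still open, from the compounds shown here alone, is how an amine or a carboxylic acid on the same aromatic carbon would read in this assay. Also open, going by these compounds, is whether trifluoromethyl gives a similar step on the core of compound 1.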